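The source may hold more compounds than are shown below. What is called first, only, known or untested is meant among the compounds shown, and "the series" means these compounds.

Compound 1 `COc1cc2c(Oc3ccc(NC(=O)c4nn(-c5ccccc5)c(=O)cc4C)cc3F)ccnc2cc1OCCCN1CCN(C)CC1` gives 2120 nM in a functional assay on U-87MG ATCC cells (Homo sapiens) for inhibition, read by MTT assay, with a stated time of 72 h; a lower number here means a stronger inhibitor, a higher number a weaker inhibitor.
Compound 2 `COc1cc2c(Oc3ccc(NC(=O)c4nn(-c5cccc(F)c5)c(=O)cc4C)cc3F)ccnc2cc1OCCCN1CCN(C)CC1` gives 1590 nM in this assay.
Compound 3 `COc1cc2c(Oc3ccc(NC(=O)c4nn(-c5ccc(Cl)cc5)c(=O)cc4C)cc3F)ccnc2cc1OCCCN1CCCC1` gives 1430 nM in this assay.

Compound 3 gives a number that sits within the scatter of both compound 2 and compound 1, so none of the three can be called stronger or weaker than another. Among the measured compounds shown here, the only single-point step among them, a 1.3-fold lower number from compound 1 to compound 2 (0.12 log units; within the scatter), concerns a different part of the molecule and stays within the scatter.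

Compound 4 `COc1cc2c(Oc3ccc(NC(=O)c4nn(-c5ccc(Cl)cc5)c(=O)cc4C)cc3F)ccnc2cc1OCCCN1CCN(C)CC1` differs from compound 3 by 4-methylpiperazin-1-yl in place of pyrrolidin-1-yl on a saturated chain carbon, three bonds along the chain from an oxygen on an aromatic ring. For the measured compounds named here, no measured pair isolates this change, since compound 1 and compound 2 carry the 4-methylpiperazin-1-yl tail but also a different aryl group. With nothing pointing to a shift beyond the scatter, compound 4 is expected to give 1600 nM in this assay, with a range of 700 nM to 3600 nM, which would mean a 1.1-fold higher number from compound 3 to compound 4 (0.05 log units; within the scatter).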

Compound 4, half-maximal inhibitory concentration: 1560 nM
Compound 4: middle estimate off by 1.0-fold (0.01 log units), on the high side; the measured number falls inside the stated range.
By their numbers in this assay, from the lowest: compounds 3, 4, 2 and 1 (each within the scatter of the next).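

With the 4-chlorophenyl group held fixed, 4-methylpiperazin-1-yl in place of pyrrolidin-1-yl on the chain gives a 1.1-fold higher number from compound 3 to compound 4 (0.04 log units; within the scatter) in this assay, so both rings are tolerated equally at this position. The aryl steps, a 1.0-fold lower number from compound 2 to compound 4 (0.01 log units; within the scatter) and a 1.4-fold lower number from compound 1 to compound 4 (0.13 log units; within the scatter), also stay within the scatter, so the chloro group shows no measurable effect here. No independent data explain these results. Still open, going by these compounds, is whether a morpholine ring or an open-chain dimethylamino group on the same propyl chain would give a number beyond the scatter.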